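This account rests on a few compounds, and the source may have more. Where it says the series, first, only, none or still open, it means among the compounds named here.

Series notes, a functional assay on K562 cells (Homo sapiens) for cytotoxicity, read by MTT assay, with a stated time of 5 days; on this read-out lower numbers stand for stronger inhibition and higher numbers for weaker inhibition:
- compound 1 `COc1ccc(-c2cnnn2-c2cc(OC)c(OC)c(OC)c2)cc1N`: 11 nM
- compound 2 `COc1ccc(Cn2nncc2-c2cc(OC)c(OC)c(OC)c2)cc1Br`: > 10000 nM (a limit)
- compound 3 `COc1ccc(-c2cnnn2Cc2cc(OC)c(OC)c(OC)c2)cc1Br`: > 10000 nM (a limit)

Compound 3 gives only a limit and no number, and compound 2 does the same. Of the data so far, (the limit of > 10000 nM in this assay, at which 2 of the 3 values shown sit).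

Compound 4 `COc1ccc(-c2cnnn2Cc2cc(OC)c(OC)c(OC)c2)cc1N` carries amino in place of bromo on an aromatic carbon of compound 3, ortho to a methoxy group: amino in place of bromo on an aromatic carbon.

Within the data shown here, no measured pair isolates this swap. Compound 1 also has the 3-amino-4-methoxyphenyl and gives 11 nM, but it differs from compound 4 elsewhere too, so it offers only weak support for a gain. The expected at least 2.0-fold lower number from compound 3 to compound 4 (0.30 log units; that floor lies within the scatter) is small, towards stronger inhibition in this assay, and it may not clear the limit. For compound 4 the estimated value is 5000 nM, with an expected range of 500 nM to 10000 nM.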

Compound 4, half-maximal inhibitory concentration: 380 nM
For compound 4 the middle estimate is 13-fold (1.12 log units) above the measured one; the whole stated range lies above it.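

With the rest of the structure unchanged, amino in place of bromo on this aromatic carbon, ortho to a methoxy group, gives an at least 26-fold lower number from compound 3 to compound 4 (1.42 log units; beyond the scatter) in this assay. This is the first single change shown at this position, and it takes the series from a limit to a measured value. The step is only a floor because the value of compound 3 is a limit: the limit of > 10000 nM in this assay, at which 2 of the 4 values shown sit.

From the compounds shown here alone, it remains open whether a hydroxyl or a methylamino group on this carbon would keep the gain. The size of the step also stays undefined until a bromo analogue gives a number.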